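Replacing the triazolylsulfanyl arm with a methylpiperazine

This account rests on a few compounds, and the source may have more. Where it says the series, first, only, none or still open, it means among the compounds named here.

Compound 1 `Cn1cnnc1SCC(=O)Nc1ccc(-c2nc(-c3ccccc3)c(-c3ccccc3)n2C)cc1` is the reference point of this pair. In a functional assay on HT-29 cells (Homo sapiens) for cytotoxicity, read by MTT assay, with a stated time of 24 h, tested at 0.64 ug/mL (a lower number here means a weaker effect, a higher number a stronger effect of the compound at the concentration tested), compound 1 gives 32%, the highest of the two numbers recorded so far; its nearest neighbour is compound 2 `Cn1c(-c2ccc(NC(=O)CSC3=NCCS3)cc2)nc(-c2ccccc2)c1-c1ccccc1`, which in this assay gives 16.8%. Going by the values given here, the one measured step between them is a number 15.2 percentage points lower from compound 1 to compound 2 (beyond the scatter), a five-membered non-aromatic ring with two hetero atoms standing in for the aromatic triazole on the sulfur.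

Compound 3 `CN1CCN(CC(=O)Nc2ccc(-c3nc(-c4ccccc4)c(-c4ccccc4)n3C)cc2)CC1` has not yet been measured. It differs from compound 1 by 4-methylpiperazin-1-yl in place of (4-methyl-4H-1,2,4-triazol-3-yl)sulfanyl on a saturated chain carbon bound to a carbonyl carbon: the (4-methyl-4H-1,2,4-triazol-3-yl)sulfanyl leaves and 4-methylpiperazin-1-yl enters on the saturated chain carbon bound to the carbonyl carbon. The step from compound 1 to compound 2 is the only measured one that touches this arm of the molecule, though there the sulfur remained and only the ring changed; here the whole group is exchanged. Because a number 15.2 percentage points lower from compound 1 to compound 2 (beyond the scatter) was the outcome of the single alteration tried on this arm, a modest loss is expected for compound 3 too, by a number 12 percentage points lower from compound 1 to compound 3 (beyond the scatter). Compound 3 is therefore estimated at 20% in this assay, with a range of 8% to 35%.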

Compound 3, a percentage reported as activity, at one concentration (the size of the read-out at that concentration, not a potency): 18.8%
Compound 3: the middle estimate sits 1.2 percentage points above what was measured; the measured number falls inside the stated range.
By their numbers in this assay, from the lowest: compounds 2 and 3 (each within the scatter of the next); then compound 1.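

In this assay, exchanging the whole (4-methyl-4H-1,2,4-triazol-3-yl)sulfanyl for 4-methylpiperazin-1-yl on a saturated chain carbon bound to a carbonyl carbon gives a number 13.2 percentage points lower from compound 1 to compound 3 (beyond the scatter), so a drop on this arm appears both with the sulfur kept, as in compound 2, and with the sulfur gone, as in compound 3. The two replacements themselves cannot be told apart, with a number 2 percentage points higher from compound 2 to compound 3 (within the scatter), and among these three compounds only compound 1, the one carrying the aromatic triazole, stands apart from the others, although a single concentration says nothing about potency. No measurement shown here bears on why the arm behaves this way.

As far as these compounds go, what remains open is whether the higher number of compound 1 goes with the aromatic ring itself or with that ring joined through sulfur, which an imidazole or a tetrazole on the sulfur, or a triazole joined directly to the chain carbon, would help to separate. From the compounds shown here alone, it is equally open whether a morpholine, a piperidine or a longer chain ahead of the piperazine would read any differently from compound 3.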